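Removing a Bromine Atom from a Hydrazone Series

A few compounds are considered here, and "the series" means these few. Any claim that something is new, unique, unknown or untested is made for them only; others in the source may bear on it.

Of the compounds shown here, three sharing one core have been tested. Compound 1 `O=C(CSc1nnc(-c2ccncc2)n1-c1ccccc1)N/N=C/c1ccccc1` carries a plain phenyl on the carbon double-bonded to nitrogen, and in a functional assay on HepG2 cells (Homo sapiens) for inhibition, read by MTT assay, with a stated time of 48 h (a higher number here means a weaker inhibitor, a lower number a stronger inhibitor), compound 1 gives 18600 nM. Compound 2 `O=C(CSc1nnc(-c2ccncc2)n1-c1ccccc1)N/N=C/c1ccc(Br)cc1` bears a bromo group on that ring; in this assay compound 2 gives 5990 nM. Compound 3 `O=C(CSc1nnc(-c2ccncc2)n1-c1ccccc1)N/N=C/c1cc(Br)ccc1O` carries both a bromo and a hydroxy group, and in this assay compound 3 gives 4390 nM.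

The change from compound 2 to compound 1 is hydrogen in place of bromo on an aromatic carbon, and its step is a 3.1-fold higher number from compound 2 to compound 1 (0.49 log units; beyond the scatter). Between compound 2 and compound 3 the difference is 5-bromo-2-hydroxyphenyl in place of 4-bromophenyl on a carbon with a double bond to nitrogen, with a 1.4-fold lower number from compound 2 to compound 3 (0.13 log units; within the scatter). The step of a 4.2-fold lower number from compound 1 to compound 3 (0.63 log units; beyond the scatter) is also recorded.

Compound 4 `O=C(CSc1nnc(-c2ccncc2)n1-c1ccccc1)N/N=C/c1ccccc1O` has not yet been measured. It differs from compound 3 by hydrogen in place of bromo on an aromatic carbon. This is the same kind of change as from compound 2 to compound 1, though the place differs: earlier the bromo sat para to a large group, here it sits meta to a large group and para to a hydroxy group. Because a 3.1-fold higher number from compound 2 to compound 1 (0.49 log units; beyond the scatter) was seen, the step is expected to be a 3.0-fold higher number from compound 3 to compound 4 (0.47 log units; beyond the scatter). Compound 4 is estimated at 13000 nM, expected between 5000 nM and 35000 nM.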

Compound 4, half-maximal inhibitory concentration: 11300 nM
For compound 4 the middle estimate is 1.2-fold (0.06 log units) above the measured one; measured number inside the range.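

Replacing bromo with hydrogen gives a weaker inhibitor on the core with the hydroxy group, with a 2.6-fold higher number from compound 3 to compound 4 (0.41 log units; beyond the scatter), and on the core without it, and the two steps agree: the same change on two cores in this assay, a 3.1-fold higher number (0.49 log units; beyond the scatter) from compound 2 to compound 1 and a 2.6-fold higher number (0.41 log units; beyond the scatter) from compound 3 to compound 4, 1.2-fold (0.08 log units) apart, within the scatter of two such steps.

The hydroxy group on its own does not separate compound 4 from its plain phenyl partner, since a 1.6-fold lower number from compound 1 to compound 4 (0.22 log units; within the scatter) stays inside the usual scatter, and a 1.9-fold higher number from compound 2 to compound 4 (0.28 log units; within the scatter) likewise does not tell those two compounds apart.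

So the bromo step carried over between these two cores in this one cell assay, but two cores cannot show that it will hold on every core in the series, and the bromo did not sit in the same place on the two rings.

Going by these compounds, it remains open whether a chloro or fluoro group in the bromo's place would give a step of similar size. On these data alone, it is equally open how an amine or a methoxy group would behave in place of the hydroxy group.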